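Acetyl on the ring nitrogen: compound 4 expectation

This account rests on a few compounds, and the source may have more. Where it says the series, first, only, none or still open, it means among the compounds named here.

Measured in a functional assay on the whole organism (plasma, strain albino) for inhibition, with Rattus norvegicus as the target, with stated times of 1 h and 4 h, at a dose of 25 mg/kg by the oral route; a higher number here means a stronger effect of the compound at the dose given, a lower number a weaker effect:
compound 1 `COc1ccc(Cl)cc1C(=O)Nc1ccc(C2=NN(C)C(c3ccccc3[N+](=O)[O-])C2)cc1`: 83.8%
compound 2 `COc1ccc(Cl)cc1C(=O)Nc1ccc(C2=NNC(c3ccccc3[N+](=O)[O-])C2)cc1`: 72.3%
compound 3 `COc1ccc(Cl)cc1C(=O)Nc1ccc(C2=NNC(c3ccc([N+](=O)[O-])cc3)C2)cc1`: 76.3%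

Compound 2 stands lowest of the three numbers. Its nearest neighbour is compound 3, with a number 4 percentage points higher from compound 2 to compound 3 (within the scatter); the furthest is compound 1, with a number 11.5 percentage points lower from compound 1 to compound 2 (beyond the scatter).

Compound 4 `COc1ccc(Cl)cc1C(=O)Nc1ccc(C2=NN(C(C)=O)C(c3ccccc3[N+](=O)[O-])C2)cc1` differs from compound 2 by acetyl in place of hydrogen on an amine nitrogen in a ring. Among the compounds with values here, the only step that bears on this place is the one from compound 1 to compound 2, where the ring nitrogen lost its methyl and gave a number 11.5 percentage points lower from compound 1 to compound 2 (beyond the scatter). Acetyl is not methyl, so that step is only a loose guide; a small upward move in this assay, hardly beyond the scatter, is expected. The estimated step is a number 7.7 percentage points higher from compound 2 to compound 4 (within the scatter). Compound 4 is therefore estimated at 80%, within a range of 66% to 91%.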

Compound 4, a percentage reported as inhibition, in the whole organism at one dose (the size of the read-out at that dose, not a potency): 77.2%
Estimate against measurement, compound 4: 2.8 percentage points above, within the range that was stated.
By their numbers in this assay, from the lowest: compounds 2, 3, 4 and 1 (each within the scatter of the next, the first and the last beyond it).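

In this assay, acetyl on the ring nitrogen gives a number 4.9 percentage points higher from compound 2 to compound 4 (within the scatter) and a number 6.6 percentage points lower from compound 1 to compound 4 (within the scatter), so this position carries a group with a carbonyl with no step beyond the scatter from either hydrogen or methyl. Earlier, this position offered only the methyl and hydrogen pair, whose step lay beyond the scatter; acetyl now lies within the scatter of both. The data offer no explanation for these steps.

Open, going by these compounds, is whether a longer acyl chain or benzoyl on this nitrogen stays within the same band. Also open, on these data alone, is whether acetyl gives a similar step alongside 4-nitrophenyl.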